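The compounds below may be only part of what the source reports. "The series", "measured", "known", "first", "only" and "open" are said of these compounds alone.

Measured in an ADME assay on microsomes from liver (Rattus norvegicus) for metabolic stability, with a stated time of 10 min, tested at 0.5 uM; a lower number here means that less of the compound is left, a higher number that more of the compound is left:
- Compound 1 `Cc1noc(C)c1[C@@H]1C[C@@](C)(c2ccccc2)N=C(N)S1`: 81%
- Compound 2 `Cc1noc(C)c1[C@@H]1C[C@@](C)(c2ccc(F)cc2)N=C(N)S1`: 78%
- Compound 3 `Cc1noc(C)c1[C@@H]1C[C@@](C)(c2sccc2Cl)N=C(N)S1`: not yet measured

In this assay, compound 2 at 78% stands level with compound 1 at 81%, within the usual scatter. The move to compound 3 puts 3-chlorothiophen-2-yl in place of 4-fluorophenyl on a saturated ring carbon. Within the data shown here, only one measured step bears on this change: a number 3 percentage points lower from compound 1 to compound 2 (within the scatter), with fluoro in place of hydrogen on an aromatic carbon. That step altered a single atom on the aromatic ring, whereas this change replaces the whole ring, so it offers only weak guidance. Among the measured compounds shown here, no measured compound shows such a replacement, and the direction remains uncertain. The expected change, not beyond the scatter, is a number 6 percentage points lower from compound 2 to compound 3 (within the scatter). For compound 3 the estimated value is 72%, with an expected range from 52% to 88%.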

Compound 3, percent of the compound remaining: 12%
Compound 3: middle estimate off by 60 percentage points, on the high side; the whole stated range lies above it.
By their numbers in this assay, from the lowest: compound 3; then compounds 2 and 1 (each within the scatter of the next).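

Read in this assay and taken at the saturated ring carbon next to the ring nitrogen, putting 3-chlorothiophen-2-yl in place of 4-fluorophenyl gives a number 66 percentage points lower from compound 2 to compound 3 (beyond the scatter) and, in place of plain phenyl, a number 69 percentage points lower from compound 1 to compound 3 (beyond the scatter) as well. So what this position carries can matter greatly: the earlier fluoro change on the aromatic ring stayed within the scatter, while exchanging the whole ring moves the amount of compound left far beyond it. Nothing shown here gives a reason for this drop.

The entering group differs from the leaving ones in both its sulfur-containing five-membered ring and its chlorine, and the compounds shown cannot separate the two. A thiophen-2-yl group without chlorine, or a phenyl ring carrying chlorine, would show which of them goes with the loss.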